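Fluorinated aryl swaps on a shared amine-bearing core

The source may report more compounds than this note shows. Statements on the series, on what has been measured and on what is new or still open speak of the compounds shown alone.

Measured so far:
- compound 1, `Nc1scc(CN2CCN(c3cccc(C(F)(F)F)c3)CC2)c1C(=O)c1ccc(Cl)cc1`: -8.2%
- compound 2, `Nc1scc(CN2CCN(c3ccccc3F)CC2)c1C(=O)c1ccc(Cl)cc1`: 2.1%

Both compounds were tested in a functional assay on CHO cells with adenosine receptor A1 (Homo sapiens) as the target, read by cAMP accumulation and immunoassay, with a stated time of 6 min, tested at 0.01 uM; on this read-out higher numbers stand for a weaker effect at the one concentration tested and lower numbers for a stronger effect. Compound 1 gives -8.2%, the lowest of the two numbers. Within the data shown here, the only measured step is a number 10.3 percentage points higher from compound 1 to compound 2 (beyond the scatter), which was counted as beyond the usual scatter but modest in size.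

Compound 3 is `Nc1scc(CN2CCN(c3c(F)cc(F)cc3F)CC2)c1C(=O)c1ccc(Cl)cc1`, not yet measured. It differs from compound 1 in one place: 2,4,6-trifluorophenyl in place of 3-(trifluoromethyl)phenyl on an amine nitrogen in a ring.

The step from compound 1 to compound 2 is the one that bears on this, since it too replaces the 3-(trifluoromethyl)phenyl on the amine nitrogen in the ring with a fluorine-bearing phenyl group. Among the measured compounds shown here, only one such step exists, so the expectation rests on a single comparison. On that basis compound 3 is expected to give a number close to, or a little higher than, compound 1, with an estimated step of a number 9.2 percentage points higher from compound 1 to compound 3 (within the scatter). The estimate for compound 3 is 1%, with a range from -12% to 14%.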

Compound 3, a percentage reported as activity, at one concentration (the size of the read-out at that concentration, not a potency): 4.2%
Beside the measured number, compound 3's estimate is 3.2 percentage points below it, and the stated range covers the measured number.
By their numbers in this assay, from the lowest: compound 1; then compounds 2 and 3 (each within the scatter of the next).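

In this assay, among these compounds, the step to the 2,4,6-trifluorophenyl group is a number 12.4 percentage points higher from compound 1 to compound 3 (beyond the scatter), so the 2-fluorophenyl group of compound 2 is no longer the only fluorinated phenyl group at this amine nitrogen to stand apart from the 3-(trifluoromethyl)phenyl group of compound 1. The step between the two fluorophenyl groups is a number 2.1 percentage points higher from compound 2 to compound 3 (within the scatter), so the two further fluorine atoms on the phenyl ring of compound 3 make no readable difference, and the three compounds fall into compound 1 on one side and compounds 2 and 3 on the other. Nothing at hand explains this split, and the size of these steps remains modest.

The compounds shown leave open whether a plain phenyl group, or a phenyl group carrying a methoxy group or a nitrile, would fall with compound 1 or with compounds 2 and 3. They also leave open how these groups compare at other concentrations, as a reading at a single concentration gives no potency, and whether the split holds when the rest of the shared core is changed.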